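Swapping the amino acid side chain: from amide to isopropyl

The source may hold more compounds than are shown below. What is called first, only, known or untested is meant among the compounds shown, and "the series" means these compounds.

Measured so far:
- Compound 1 `O=C(CN(c1nc(Cl)nc2[nH]cnc12)C1CC1)N[C@@H](CCC(=O)OCc1ccccc1)C(=O)OCc1ccccc1`: 53.7%
- Compound 2 `NC(=O)C[C@H](NC(=O)CN(c1nc(Cl)nc2[nH]cnc12)C1CC1)C(=O)O`: 43.1%
- Compound 3 `NCCCC[C@H](NC(=O)CN(c1nc(Cl)nc2[nH]cnc12)C1CC1)C(=O)OCc1ccccc1`: 41.2%

All three share one core and differ in the amino acid part attached through an amide. In a functional assay on the whole organism (Tail, strain ICR) with Mus musculus as the target, in the tail flick test, with a stated time of 60 min, at a dose of 25 umol/kg by the oral route (a lower number here means a weaker effect, a higher number a stronger effect of the compound at the dose given), compound 1 gives 53.7%, compound 2 gives 43.1% and compound 3 gives 41.2%. Compound 2 stands second of the three: its number is beyond the scatter below compound 1, while compound 3 lies within the scatter of it, so no order between compound 2 and compound 3 can be read.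

Compound 4 `CC(C)[C@H](NC(=O)CN(c1nc(Cl)nc2[nH]cnc12)C1CC1)C(=O)O` arises from compound 2 by isopropyl in place of carbamoylmethyl on a saturated chain carbon bound to an amide-type nitrogen and a carbonyl carbon.

For the measured compounds named here, only one measured step touches this side chain region: a number 12.5 percentage points lower from compound 1 to compound 3 (beyond the scatter). That change sat further out along the chain and also altered the ester, so it does not speak directly to the present swap. Nothing measured compares a carbamoylmethyl with an isopropyl at this carbon. The expectation is therefore a step within the scatter, estimated as a number 1.9 percentage points higher from compound 2 to compound 4 (within the scatter). Compound 4 is estimated at 45%, with a range from 30% to 60%.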

Compound 4, a percentage reported as activity, at one dose (the size of the read-out at that dose, not a potency): 38.8%
The estimate for compound 4 lay 6.2 percentage points above the measured number, within the range that was stated.
By their numbers in this assay, from the lowest: compounds 4, 3 and 2 (each within the scatter of the next); then compound 1.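

In this assay, for the compounds shown here, swapping carbamoylmethyl for isopropyl gives a number 4.3 percentage points lower from compound 2 to compound 4 (within the scatter), the only direct comparison of two groups on this saturated chain carbon. It shows that the two groups are not told apart at this dose, even though carbamoylmethyl has a hydrogen-bond donor and acceptor and isopropyl has neither. Nothing available explains this outcome.

What a benzyl group or a hydroxymethyl group on this carbon would give in this assay remains open, as neither appears among the compounds shown. Also open, on these data alone, is whether replacing the free carboxylic acid of compound 4 with a benzyl ester would shift the read-out, since compound 4 has no partner that differs from it in that one place.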